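Extending the cyclohexyl ring of a receptor ligand

The source may report more compounds than this note shows. Statements on the series, on what has been measured and on what is new or still open speak of the compounds shown alone.

Compound 1 `Cc1cc2c(cc1Cc1ccc(C(=O)NCC3CCCCC3)o1)C(C)(C)CCC2(C)C`: in an assay on isolated protein for binding affinity to Gonadotropin-releasing hormone receptor (Homo sapiens) (a lower number here means a stronger inhibitor, a higher number a weaker inhibitor), compound 1 gives 180 nM.
Compound 2 `Cc1cc2c(cc1Cc1ccc(C(=O)NCc3ccccc3)o1)C(C)(C)CCC2(C)C`: in this assay compound 2 gives 102 nM.

Of these two numbers, that of compound 1 is the larger, but the distance to compound 2 lies within the scatter: a 1.8-fold lower number from compound 1 to compound 2 (0.25 log units; within the scatter). Compound 3 `Cc1cc2c(cc1Cc1ccc(C(=O)NCC3CCC(CNCc4c(C)noc4C)CC3)o1)C(C)(C)CCC2(C)C` arises from compound 1 by (((3,5-dimethyl-1,2-oxazol-4-yl)methyl)amino)methyl in place of hydrogen on a saturated ring carbon. For the measured compounds named here, no measured step adds a group to that ring; the only step seen, a 1.8-fold lower number from compound 1 to compound 2 (0.25 log units; within the scatter), exchanges the ring itself and stays within the scatter, so it gives little guidance. The expected step is therefore a 1.1-fold higher number from compound 1 to compound 3 (0.05 log units; within the scatter), none beyond the scatter. Compound 3 is estimated at 200 nM, with a range from 60 nM to 650 nM.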

Compound 3, inhibition constant: 180 nM
The estimate for compound 3 lay 1.1-fold (0.05 log units) above the measured number, and the stated range covers the measured number.
By their numbers in this assay, from the lowest: compounds 2, 1 and 3 (each within the scatter of the next).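

Compound 1 carries a large addition on its saturated ring without a measurable loss: with (((3,5-dimethyl-1,2-oxazol-4-yl)methyl)amino)methyl in place of hydrogen, this assay shows no change at the digits printed from compound 1 to compound 3 (within the scatter) for this change. The earlier pair only exchanged one ring for another, whereas this step shows that a group bearing a five-membered aromatic ring can sit on a saturated ring carbon, three ring bonds from the ring atom that bears a large group. No measurement here explains why the number holds. On these data alone, whether a simple aminomethyl or a carboxylic acid at this place would shift the number remains open.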